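The compounds below may be only part of what the source reports. "The series", "measured", "known", "first", "only" and "open" are said of these compounds alone.

Of the compounds shown here, two have numbers so far in a functional assay on cells (Cancer cell lines, Homo sapiens) for inhibition, with a stated time of 48 h; a higher number here means a weaker inhibitor of growth, a lower number a stronger inhibitor of growth. Compound 1 (`COc1cc2c(/C=C3/C(=O)Nc4cc(Cl)ccc43)c(Cl)[nH]c2cc1C`) gives 170 nM. Compound 2 (`COc1cc2c(/C=C3/C(=O)N(C)c4ccccc43)c[nH]c2cc1C`) gives 760 nM, the higher of the two numbers, and its gap to compound 1 lies beyond the scatter. Among the compounds with values here, no pair of measured compounds differs in one place only, so no measured step bears directly on the next compound.

Compound 3 (`COc1cc2c(/C=C3/C(=O)N(C)c4ccc(O)cc43)c[nH]c2cc1C`) differs from compound 2 in one place: hydroxy in place of hydrogen on an aromatic carbon. Within the data shown here, no measured compound carries a hydroxy group, so the direction of this change cannot be read from the data. The expectation is a modest step, possibly none beyond the scatter, with a slight lean toward a lower number in this assay. The expected size of the change is a 1.5-fold lower number from compound 2 to compound 3 (0.18 log units; within the scatter). In this assay the estimate for compound 3 is 500 nM, with an expected range from 140 nM to 1800 nM.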

Compound 3, concentration for 50% growth inhibition: 2950 nM
Beside the measured number, compound 3's estimate is 5.9-fold (0.77 log units) below it, outside the stated range (above it).
By their numbers in this assay, from the lowest: compound 1; then compound 2; then compound 3.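

In this assay the series now has its first one-place step, and hydroxy in place of hydrogen gives a 3.9-fold higher number from compound 2 to compound 3 (0.59 log units; beyond the scatter) with weaker growth inhibition as the outcome. This aromatic carbon, meta to a fused ring and para to a fused ring, is therefore not indifferent to substitution: a single added oxygen atom moves the number beyond the scatter, and in the unfavourable direction. No supporting data bear on why the step goes this way, so it stands as an observation on compound 2 and compound 3 alone.

The compounds shown leave open whether this loss belongs to the hydroxy group in particular or would follow from any group on this carbon, and a fluorine atom, an amine or a carboxylic acid in the same place would separate those readings. Also open, from the compounds shown here alone, is whether the same change would carry the same penalty on a different member of the series, such as one with the amide hydrogen in place of the methyl group on the amide nitrogen.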